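This account rests on a few compounds, and the source may have more. Where it says the series, first, only, none or still open, it means among the compounds named here.

Compound 2 `C[Se]/C(=N\C(=O)c1cc(-c2ccccc2)nc2ccccc12)NC(=O)c1cc(-c2ccccc2)nc2ccccc12` and compound 1 `CS/C(=N\C(=O)c1cc(-c2ccccc2)nc2ccccc12)NC(=O)c1cc(-c2ccccc2)nc2ccccc12` share a core and differ in one place: a group of 2 heavy atoms (1 carbon, 1 sulfur; no ring) in place of a group of 2 heavy atoms (1 carbon, 1 selenium; no ring), on a carbon with a double bond to nitrogen. In a functional assay on HepG2 cells (Homo sapiens) for cytotoxicity, read by MTT assay, with a stated time of 72 h (a higher number here means a weaker inhibitor of growth, a lower number a stronger inhibitor of growth), compound 2 gives 10100 nM, and compound 1 gives 48200 nM, so the change brings a 4.8-fold higher number from compound 2 to compound 1 (0.68 log units; beyond the scatter). Compound 3 `C[Se]/C(=N\C(=O)c1cnc2ccccc2c1)NC(=O)c1cnc2ccccc2c1` carries the same selenium-bearing group on a smaller core; how its core differs from that of compound 2 is not broken down here. In this assay compound 3 gives 23700 nM, a number that stands between those of compound 2 and compound 1.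

Compound 4 `CS/C(=N\C(=O)c1cnc2ccccc2c1)NC(=O)c1cnc2ccccc2c1` is not yet measured. It differs from compound 3 by a group of 2 heavy atoms (1 carbon, 1 sulfur; no ring) in place of a group of 2 heavy atoms (1 carbon, 1 selenium; no ring), on a carbon with a double bond to nitrogen. This is the same change as that from compound 2 to compound 1, at the same kind of carbon with the same neighbours. Among the compounds with values here, the expectation for compound 4 rests on that one earlier step alone, because a 4.8-fold higher number from compound 2 to compound 1 (0.68 log units; beyond the scatter) is the only measured example of the change, and it is carried over to compound 3 as a step of about a 3.8-fold higher number from compound 3 to compound 4 (0.58 log units; beyond the scatter). On that basis compound 4 is estimated at 90000 nM in this assay, expected to fall between 35000 nM and 230000 nM.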

Compound 4, concentration for total growth inhibition: > 100000 nM
Compound 4 ended at the assay's limit; the forecaster's own chance of this, stated with the estimate: 30%; at least 1.1-fold (0.04 log units) between middle value and limit.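

In this assay, putting methylsulfanyl in place of the selenium-bearing group on the core of compound 3 gives an at least 4.2-fold higher number from compound 3 to compound 4 (0.62 log units; beyond the scatter), so the number moves the same way on both cores: the same change on two cores in this assay, a 4.8-fold higher number (0.68 log units; beyond the scatter) from compound 2 to compound 1 and an at least 4.2-fold higher number (0.62 log units; beyond the scatter) from compound 3 to compound 4; the limit leaves it open whether they differ Compound 4 reads > 100000 nM, which is a limit of the assay and not a number: the limit of > 100000 nM in this assay, at which 1 of the 4 values shown sits. The two cores therefore show that the direction of this change carried over from one core to the other, but they do not show how closely the sizes match, and two cores cannot establish that the change would behave the same way on every core in this series.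

The compounds shown carry only methylsulfanyl or its selenium-bearing counterpart on this carbon, so it remains open how a longer chain such as ethylsulfanyl, or an amine, would read there. Going by these compounds, it also remains open whether the same step would appear on a third core.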